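The source may hold more compounds than are shown below. What is called first, only, known or untested is meant among the compounds shown, and "the series" means these compounds.

Compound 1 `O=C(/C=C\Nc1ccc(C(F)(F)F)cc1)c1cn(-c2ccccc2)nc1-c1ccccc1` is the reference point of this small set. In a functional assay on PC-3 cells (Homo sapiens) for antiproliferative activity, read by MTT assay, with a stated time of 48 h (a higher number here means a weaker inhibitor, a lower number a stronger inhibitor), compound 1 gives only a limit, > 50000 nM; (the limit of > 50000 nM in this assay, at which 1 of the 3 values shown sits). Compound 2 `O=C(/C=C\Nc1ccc(O)cc1)c1cn(-c2ccccc2)nc1-c1ccccc1` carries hydroxy where compound 1 carries trifluoromethyl, and in this assay compound 2 gives 3600 nM. Compound 3 `COc1ccc(N/C=C\C(=O)c2cn(-c3ccccc3)nc2-c2ccccc2)cc1` carries methoxy in the same place, and in this assay compound 3 gives 6400 nM. The measured steps read an at least 13-fold lower number from compound 1 to compound 2 (1.14 log units; beyond the scatter) and an at least 7.8-fold lower number from compound 1 to compound 3 (0.89 log units; beyond the scatter); between the two numbers proper, a 1.8-fold higher number from compound 2 to compound 3 (0.25 log units; within the scatter). Compound 2 thus holds the lowest of the two numbers, with compound 3 within the scatter of it and compound 1 sitting at a limit.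

Compound 4 `O=C(/C=C\Nc1ccc(O)cc1)c1cn(-c2ccccc2)nc1-c1ccc(F)cc1` differs from compound 2 in fluoro in place of hydrogen on an aromatic carbon. For the measured compounds named here, none of the measured steps touches this ring; all three alter the group on the other aromatic ring, so no step bears directly on the change. With nothing pointing either way, the expectation is that fluoro in place of hydrogen gives no step beyond the scatter in this assay. The expected step of no change at the digits printed from compound 2 to compound 4 (within the scatter) is therefore taken as small. For compound 4 in this assay the estimate is 3600 nM, with a range from 1500 nM to 9000 nM.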

Compound 4, half-maximal inhibitory concentration: 2600 nM
Beside the measured number, compound 4's estimate is 1.4-fold (0.14 log units) above it; the measured number falls inside the stated range.
By their numbers in this assay, from the lowest: compounds 4, 2 and 3 (each within the scatter of the next, the first and the last beyond it). At a limit, above all of these: compound 1.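

For the compounds shown here, compound 4 is the first compound here to change the ring that stayed a plain phenyl through compounds 1 to 3. In this assay phenyl to 4-fluorophenyl gives a 1.4-fold lower number from compound 2 to compound 4 (0.14 log units; within the scatter) and so shows that this carbon, para to a large group, takes a fluoro without a step beyond the scatter. The earlier steps all sat on the other aromatic ring, where only the two steps leaving trifluoromethyl went beyond the scatter, and no measurement at hand bears on what lies behind the fluoro step.

Going by these compounds alone, with compound 2 and compound 4 as the only pair on this ring, it remains open whether chloro, an amine, a carboxylic acid or a longer chain on the same carbon would also stay within the scatter, or whether the tolerance seen here is confined to fluoro. It also remains open whether the same fluoro change would read alike with methoxy on the other ring, as in compound 3, since the only pair shown carries hydroxy there.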